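The compounds below may be only part of what the source reports. "The series", "measured", "known", "first", "only" and "open" are said of these compounds alone.

Working notes on the series. The core is shared by compound 1 `CCCCOc1ccc(-c2nc3ncccn3c2NCc2c[nH]cn2)cc1`, compound 2 `CCCCOc1ccc(-c2c(NC(C)(C)CC(C)(C)C)nc3ncccn23)cc1` and compound 3 `COCCCCOc1ccc(-c2nc3ncccn3c2NC2CCCCC2)cc1`, all three run in a toxicity assay on A549 cells (Homo sapiens) for cytotoxicity, read by luminescence and CellTiter-Glo, with a stated time of 48 h; a lower number here means that less compound is tolerated, a higher number that more compound is tolerated. For compound 1 the result in this assay is a limit, > 100000 nM, and not a number; this is the situation described in the limit of > 100000 nM in this assay, at which 1 of the 3 values shown sits. Compound 2 gives 49000 nM in this assay. Compound 3 gives 100000 nM in this assay, the higher of the two numbers available, and the gap to compound 2 lies beyond the usual scatter.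

Compound 4 `Oc1ccc(-c2nc3ncccn3c2NC2CCCCC2)cc1` has not yet been measured in this assay. Relative to compound 3 the change is hydrogen in place of 4-methoxybutyl on an oxygen on an aromatic ring. For the measured compounds named here, no pair of measured compounds differs in a single place, so the size of this step cannot be taken from a measured one. What can be said is that the numbers sit at the upper edge of what this assay resolves, with compound 2 at 49000 nM and compound 3 at 100000 nM. For compound 4 the expectation is therefore a step of no change at the digits printed from compound 3 to compound 4 (within the scatter), nothing beyond the scatter, in either direction. Compound 4 is estimated at 100000 nM in this assay, within a range from 45000 nM to 200000 nM, with a real chance that only a limit is reported.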

Compound 4, half-maximal cytotoxic concentration: > 100000 nM
Compound 4: only a limit was reported; the forecaster's own chance of this, stated with the estimate: 50%; the middle value sits exactly at the limit.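

For the compounds shown here, this is the first single-place step that can be followed in this assay: hydrogen in place of 4-methoxybutyl on an oxygen on an aromatic ring gives a number no lower from compound 3 to compound 4 (the limit leaves the size open). Stripping the whole chain back to hydroxy therefore does not bring the number down, so with the rest of compound 3 held constant, the 4-methoxybutyl group is not needed for the high tolerance seen here. The direction of the step can be read, but its size cannot, because compound 4 is a limit and not a number and the series is gathering at the top of the assay's range: the limit of > 100000 nM in this assay, at which 2 of the 4 values shown sit.

Still open, as far as these compounds go, is whether any group on this oxygen can bring the number clearly down, for example a methoxy group, or a longer chain ending in an amine or a carboxylic acid. Going by these compounds alone, also open is whether hydroxy in place of the butoxy group of compound 1 or compound 2 would give a step in the same direction, since the only step read so far rests on the remainder of compound 3.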